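Anticipated cytotoxicity of the methoxybenzyl analogue of compound 3

The source may hold more compounds than are shown below. What is called first, only, known or untested is meant among the compounds shown, and "the series" means these compounds.

Compound 1 `O=c1c(O)c(-c2ccccc2)oc2cc(OCc3cccc(Br)c3)cc(O)c12`: in an ADME assay on Huh-5-2 cells (Homo sapiens) for cytotoxicity, read by WST assay, with a stated time of 3 days (a lower number here means that less compound is tolerated, a higher number that more compound is tolerated), compound 1 gives > 100000 nM, which is a limit of the assay and not a number.
Compound 2 `O=c1c(O)c(-c2ccccc2)oc2cc(OCc3ccc(Cl)cc3)cc(O)c12`: in this assay compound 2 gives > 100000 nM, again a limit of the assay.
Compound 3 `Cc1ccc(COc2cc(O)c3c(=O)c(O)c(-c4ccccc4)oc3c2)cc1`: in this assay compound 3 gives 88000 nM.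

Going by the values given here, compound 3 thus carries the only number among the three values; the other two sit at the limit of > 100000 nM in this assay, at which 2 of the 3 values shown sit. The step of an at least 1.1-fold lower number from compound 1 to compound 3 (0.05 log units; that floor lies within the scatter) and the step of an at least 1.1-fold lower number from compound 2 to compound 3 (0.05 log units; that floor lies within the scatter) are both readable only as floors, and both floors lie within the scatter, so none of the three compounds is separated from the others beyond it. The step that the two limits leave unreadable from compound 1 to compound 2 cannot be sized at all.

Compound 4 `COc1ccc(COc2cc(O)c3c(=O)c(O)c(-c4ccccc4)oc3c2)cc1` differs from compound 3 by methoxy in place of methyl on an aromatic carbon. Among the compounds with values here, no measured step exchanges methyl for methoxy; the nearest is the step from chloro to methyl, which was not resolved beyond the scatter. Compound 4 is therefore expected to show no change beyond the scatter, with the estimated step of a 1.1-fold higher number from compound 3 to compound 4 (0.03 log units; within the scatter) in this assay. For compound 4 the estimate is 95000 nM, with a range from 50000 nM to 200000 nM, and a fair chance that the assay again reports only a limit.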

Compound 4, half-maximal cytotoxic concentration: > 100000 nM
Compound 4: only a limit was reported (the forecaster's own chance of this, stated with the estimate: 50%); at least 1.0-fold (0.02 log units) between middle value and limit.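

The exchange of methyl for methoxy on the 4-methylbenzyl group, not covered by any earlier step, reads as an at least 1.1-fold higher number from compound 3 to compound 4 (0.05 log units; that floor lies within the scatter); this is only a floor and does not separate the two compounds. The steps to compound 4 from compound 1 and from compound 2 cannot be read at all, as each joins two limits. The new result shows that this position, on an aromatic carbon para to a large group, also takes a methoxy, which brings an oxygen and a hydrogen-bond acceptor by the count, without the read-out leaving the limit that already held for the 3-bromophenyl and 4-chlorophenyl compounds: the limit of > 100000 nM in this assay, at which 3 of the 4 values shown sit.

Going by these compounds alone, compound 3 remains the only compound with a number in this assay, so how far the other three lie from it, and whether any change at this position matters beyond the scatter, stays open. On these data alone, it is also open whether an amine, a carboxylic acid or a longer chain in place of the methoxy would give a number clearly separated from that limit.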